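This account rests on a few compounds, and the source may have more. Where it says the series, first, only, none or still open, it means among the compounds named here.

Measured compounds:
- compound 1 `C/C(C#CCN1CCC(n2c(=O)[nH]c3ccccc32)CC1)=C\COc1ccc2ccc(=O)oc2c1`: 2500 nM
- compound 2 `C/C(C#CCN1CCN(C(c2ccc(F)cc2)c2ccc(F)cc2)CC1)=C\COc1ccc2ccc(=O)oc2c1`: 47000 nM

In a functional assay on LoVo cells (Homo sapiens) for inhibition, read by MTT assay, with a stated time of 24 h (a higher number here means a weaker inhibitor, a lower number a stronger inhibitor), compound 1 gives 2500 nM, the lower of the two numbers recorded so far. Compound 2 gives 47000 nM in this assay, a markedly higher number than compound 1, and the gap between the two lies beyond the usual scatter of repeated measurements. Among the measured compounds shown here, no step between these two compounds has been worked out, as they differ in more than one place; only the two values themselves are known.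

Compound 3 `C/C(C#CCN1CCCCC1)=C\COc1ccc2ccc(=O)oc2c1` has not yet been measured in this assay. Relative to compound 1 the change is a hydrogen atom in place of a group of 10 heavy atoms (7 carbon, 2 nitrogen, 1 oxygen; one five-membered aromatic ring with 2 hetero atoms, one six-membered aromatic ring of carbon only), on a saturated ring carbon, in words: a hydrogen atom in place of a group of 10 heavy atoms (7 carbon, 2 nitrogen, 1 oxygen; one five-membered aromatic ring with 2 hetero atoms, one six-membered aromatic ring of carbon only), on a saturated ring carbon. Removing so large a part of compound 1 is expected to cost potency, with a step of a 4.8-fold higher number from compound 1 to compound 3 (0.68 log units; beyond the scatter) towards a higher number. Compound 3 is therefore estimated at 12000 nM in this assay, in the range 3000 nM to 45000 nM.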

Compound 3, half-maximal inhibitory concentration: 62000 nM
Beside the measured number, compound 3's estimate is 5.2-fold (0.71 log units) below it; measured number outside the range, above it.
By their numbers in this assay, from the lowest: compound 1; then compounds 2 and 3 (each within the scatter of the next).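

In this assay, among the compounds shown here, a hydrogen atom in place of the group of 10 heavy atoms on the saturated ring carbon gives a 25-fold higher number from compound 1 to compound 3 (1.39 log units; beyond the scatter), the first single change that can be read. The position, three ring bonds from the ring nitrogen, is therefore not indifferent to this change: the number of compound 1, 2500 nM, is reached only with the group carrying the five-membered aromatic ring with 2 hetero atoms and the six-membered aromatic ring of carbon only, and is lost when the group leaves. No supporting data are at hand to account for the size of this step.

This single pair does not show how much of the group is needed, and a smaller substituent on the same carbon, such as a phenyl ring, a hydroxyl or a primary amine, would divide the step into parts. Also open, on these data alone, is the part played by the hydrogen-bond donor counted in the group, which a methyl group in place of that hydrogen would address.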